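The compounds below may be only part of what the source reports. "The series", "measured", "known", "first", "only" and "open" are said of these compounds alone.

Three compounds share one core and differ only in the group attached to one aromatic carbon. Compound 1 `Cn1ncnc1-c1cc(Oc2ccc(NC(=O)Nc3cccc(C(F)(F)F)c3)cc2F)ccn1` gives 11600 nM in a functional assay on NCI-H460 cells (Homo sapiens) for antiproliferative activity, read by MTT assay, with a stated time of 72 h; on this read-out lower numbers stand for stronger inhibition and higher numbers for weaker inhibition. Compound 2 `CCN(CC)CCn1cnnc1-c1cc(Oc2ccc(NC(=O)Nc3cccc(C(F)(F)F)c3)cc2F)ccn1` gives 9870 nM in this assay, and its step from compound 1 is a 1.2-fold lower number from compound 1 to compound 2 (0.07 log units; within the scatter). Compound 3 `CN(C)CCCn1cnnc1-c1cc(Oc2ccc(NC(=O)Nc3cccc(C(F)(F)F)c3)cc2F)ccn1` gives 1790 nM, the lowest of the three numbers: it stands a 6.5-fold lower number from compound 1 to compound 3 (0.81 log units; beyond the scatter) and a 5.5-fold lower number from compound 2 to compound 3 (0.74 log units; beyond the scatter), both beyond the scatter, so compound 3 is the most potent of the three.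

Compound 4 `CN(C)CCCn1cnnc1-c1cc(Oc2ccc(NC(=O)Nc3ccc(Cl)cc3Cl)cc2F)ccn1` keeps everything in compound 3 except the aryl group on the amide-type nitrogen: 2,4-dichlorophenyl in place of 3-(trifluoromethyl)phenyl on an amide-type nitrogen. None of the three measured steps touches this part of the molecule; each of them alters the substituent at the other end of the core, and each leaves the 3-(trifluoromethyl)phenyl group in place. Among the compounds with values here, there is thus no measured step of the same kind to lean on, and no basis for a direction. With that caveat, the step from compound 3 to compound 4 is expected to stay within the scatter, with an expected size of a 1.4-fold higher number from compound 3 to compound 4 (0.15 log units; within the scatter). For compound 4, the estimated value in this assay is 2500 nM, with a range from 700 nM to 9000 nM.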

Compound 4, half-maximal inhibitory concentration: 3680 nM
Compound 4: the middle estimate sits 1.5-fold (0.17 log units) below what was measured, within the range that was stated.
By their numbers in this assay, from the lowest: compound 3; then compound 4; then compounds 2 and 1 (each within the scatter of the next).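

Within the data shown here, the aryl group on the amide-type nitrogen stayed the same in compounds 1 to 3, so only this new comparison tests it. In this assay, placing 2,4-dichlorophenyl where 3-(trifluoromethyl)phenyl stood gives a 2.1-fold higher number from compound 3 to compound 4 (0.31 log units; beyond the scatter), which shows that this position also affects antiproliferative potency, although this single change has only a modest effect and leaves compound 3 with the lower number. No measurement is available to explain this difference between the two aryl groups.

This single swap removes the trifluoromethyl group and adds two chlorine atoms, so the two compounds cannot separate the contribution of either substituent or of where each one sits on the phenyl ring. From the compounds shown here alone, it remains open where a plain phenyl, a 4-chlorophenyl or a 3-chlorophenyl group would fall relative to these two aryl groups, and whether 2,4-dichlorophenyl would produce a step of similar size and direction when paired with the diethylaminoethyl chain of compound 2 or the methyl group of compound 1.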